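The source may hold more compounds than are shown below. What is called first, only, known or untested is meant among the compounds shown, and "the series" means these compounds.

Measured so far in a functional assay on A549 cells (Homo sapiens) for antiproliferative activity, read by MTT assay, with a stated time of 72 h; on this read-out higher numbers stand for weaker inhibition and lower numbers for stronger inhibition:
- compound 1 `Cc1ccc(-c2cn(C/C=C3\OC(=O)C(OCc4ccccc4)=C3OCc3ccccc3)nn2)cc1`: in this assay compound 1 gives > 100000 nM, a limit of the assay and not a number.
- compound 2 `CC(C)(C)c1cn(C[C@H](O)[C@H]2OC(=O)C(OCc3ccccc3)=C2OCc2ccccc2)nn1`: in this assay compound 2 gives 34000 nM.

Within the data shown here, compound 2 carries the only number in this assay; compound 1 sits at the limit of > 100000 nM in this assay, at which 1 of the 2 values shown sits. Both measured compounds share the same core with its two benzyloxy substituents, and compound 2 is the one with the hydroxyl-bearing linker between the core and the triazole ring.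

Compound 3 `O=C1O[C@H]([C@@H](O)Cn2cc(CCO)nn2)C(OCc2ccccc2)=C1OCc1ccccc1` has not yet been measured in this assay. Set against compound 2, the change is 2-hydroxyethyl in place of tert-butyl on an aromatic carbon. Among the measured compounds shown here, no step between measured compounds is available that isolates this change, so there is no measured anchor for its size. The expectation is a step of no more than modest size from compound 2 to compound 3, with the direction open and weaker inhibition at least as likely as stronger, given that compound 2 already sits at a weak level; the expected step is a 1.8-fold higher number from compound 2 to compound 3 (0.25 log units; within the scatter). Compound 3 is accordingly estimated at 60000 nM in this assay, with a range from 15000 nM to 200000 nM, and a real chance that only a limit is returned.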

Compound 3, half-maximal inhibitory concentration: > 100000 nM
Compound 3: only a limit was reported; the forecaster's own chance of this, stated with the estimate: 35%; middle value at least 1.6-fold (0.22 log units) from the limit.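

In this assay, among these compounds, the aromatic carbon of the triazole ring is the first place where a single change can be read: 2-hydroxyethyl in place of tert-butyl gives an at least 2.9-fold higher number from compound 2 to compound 3 (0.46 log units; beyond the scatter). This position therefore does not tolerate every group, and the measurable inhibition of compound 2 is lost with this one exchange, although the two groups are of similar size by heavy-atom count. Compound 3 is reported only as a limit, so the step has a lower bound and no upper one, and two of the compounds shown now rest at that same limit: the limit of > 100000 nM in this assay, at which 2 of the 3 values shown sit.

The compounds shown do not separate the effect of removing tert-butyl from the effect of introducing the hydroxyl of the 2-hydroxyethyl group. On these data alone, an n-butyl or isopropyl chain on the same carbon would speak to the first question, while a 2-methoxyethyl or 2-aminoethyl group would show whether the end of the chain matters, and whether any group here can improve on compound 2 remains open.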